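Working notes: phenyl to hydroxy on the shared core

The source may report more compounds than this note shows. Statements on the series, on what has been measured and on what is new or still open speak of the compounds shown alone.

Three compounds share one core and differ only in the group on one aromatic carbon. Compound 1 `O=C(/C=C/c1ccc2c(c1)B(O)OC2)c1ccc(-c2ccccc2)cc1` carries phenyl there; in a functional assay on HCT-116 cells (Homo sapiens) for cytotoxicity, read by MTT assay, with a stated time of 48 h (a higher number here means a weaker inhibitor, a lower number a stronger inhibitor), compound 1 gives 9500 nM. Compound 2 `O=C(/C=C/c1ccc2c(c1)B(O)OC2)c1ccc(I)cc1` carries iodo, and in this assay compound 2 gives 11600 nM. Compound 3 `CSc1ccc(C(=O)/C=C/c2ccc3c(c2)B(O)OC3)cc1` carries methylsulfanyl, and in this assay compound 3 gives 10300 nM. Compound 1 has the lowest of the three numbers, but both its nearest neighbour, compound 3, and its furthest, compound 2, lie within the scatter of it, so no order among the three can be read.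

Compound 4 `O=C(/C=C/c1ccc2c(c1)B(O)OC2)c1ccc(O)cc1` is not yet measured. It differs from compound 1 as follows: hydroxy in place of phenyl on an aromatic carbon. Among the measured compounds shown here, the steps that bear on it are the two that also exchange the phenyl on this carbon: a 1.2-fold higher number from compound 1 to compound 2 (0.09 log units; within the scatter) and a 1.1-fold higher number from compound 1 to compound 3 (0.04 log units; within the scatter). Both are within the scatter, so two unlike replacements of phenyl at this carbon left the number where it was. Whether hydroxy behaves like these two is not tested among the measured compounds, so the expectation rests on the two flat steps alone. The step expected is a 1.2-fold higher number from compound 1 to compound 4 (0.06 log units; within the scatter), that is, none beyond the scatter. For compound 4 the estimate in this assay is 11000 nM, with a range from 5000 nM to 25000 nM.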

Compound 4, half-maximal inhibitory concentration: 24100 nM
For compound 4 the middle estimate is 2.2-fold (0.34 log units) below the measured one; measured number inside the range.
By their numbers in this assay, from the lowest: compounds 1, 3 and 2 (each within the scatter of the next); then compound 4.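

In this assay, among the compounds shown here, this aromatic carbon proved not to be indifferent to its group: hydroxy is the first replacement to move the number beyond the scatter, giving a 2.5-fold higher number from compound 1 to compound 4 (0.40 log units; beyond the scatter) and a 2.3-fold higher number from compound 3 to compound 4 (0.37 log units; beyond the scatter) as well as a 2.1-fold higher number from compound 2 to compound 4 (0.32 log units; beyond the scatter) in steps that are all modest. For the compounds shown here, the flat picture among phenyl, iodo and methylsulfanyl therefore holds for those three groups only and cannot be extended to every group at this carbon, with compound 4 the one compound that goes against it. Against phenyl, the change removes a six-membered aromatic ring of carbon only and brings in a hydrogen-bond donor and acceptor, but the four compounds do not separate these features from one another, and no measurement at hand explains the step.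

From the compounds shown here alone, whether the higher number is particular to hydroxy or is shared by other groups on this carbon, such as methoxy, an amine or a carboxylic acid, remains open. Also open, going by these compounds, is whether a group as small as fluoro would stay with phenyl, iodo and methylsulfanyl or move with hydroxy, which would help to separate the loss of the ring from the arrival of the hydroxy group.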